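Amide to Sulfonamide on a Shared Chiral Core

The source may hold more compounds than are shown below. What is called first, only, known or untested is meant among the compounds shown, and "the series" means these compounds.

The study centres on compound 1, `C[C@@H](Cn1ccc(-c2ccc(C#N)c(Cl)c2)n1)NC(=O)c1ccccc1`; in a functional assay on VCaP cells (Homo sapiens) for antiproliferative activity, read by CCK-8 assay, with a stated time of 6 days (on this read-out lower numbers stand for stronger inhibition and higher numbers for weaker inhibition), compound 1 gives "not determined" (no result reported), so no number stands against it there. The nearest measured point is compound 2, `COc1ccc(C(=O)N[C@@H](C)Cn2ccc(-c3ccc(C#N)c(Cl)c3)n2)cc1`, which differs from compound 1 by a methoxy group on the benzoyl ring; in this assay compound 2 gives 1540 nM. With no value for compound 1 itself, compound 2 is the only anchor for judging where this series sits.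

The unmeasured compound 3, `C[C@@H](Cn1ccc(-c2ccc(C#N)c(Cl)c2)n1)NS(=O)(=O)c1cccnc1`, is reached from compound 1 by a single change: (pyridin-3-yl)sulfonyl in place of benzoyl on an amine nitrogen. For the measured compounds named here, no step between measured compounds speaks to this change, so its size in this assay cannot be read from the data; a shift of modest size in either direction, or none beyond the usual scatter, is all that can be expected.

Resting on the single value of compound 2, compound 3 is estimated to give about 1500 nM in this assay, with a range from 300 nM to 8000 nM, the width reflecting that compound 1 itself carries no number.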

Compound 3, half-maximal inhibitory concentration: 2450 nM
Compound 3: the middle estimate sits 1.6-fold (0.21 log units) below what was measured; the measured number falls inside the stated range.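

In this assay, for the compounds shown here, compound 3 gives 2450 nM while compound 1 gives "not determined" (no result reported) and so no step between the two can be read. The compounds shown leave open how (pyridin-3-yl)sulfonyl in place of benzoyl on the shared core moves this read-out. No measured evidence bears on the result for compound 3.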